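A Ring Swap on the Triple-Bonded Carbon

The source may report more compounds than this note shows. Statements on the series, on what has been measured and on what is new or still open speak of the compounds shown alone.

Three compounds have been measured in a functional assay on HEK293 cells for positive allosteric modulation of metabotropic glutamate receptor 5 (Rattus norvegicus), read by fluorescence and calcium flux; on this read-out lower numbers stand for smaller maximal responses and higher numbers for larger maximal responses:
compound 1 `C[C@@H](NC(=O)c1ccc(C#Cc2ccc(F)cc2)cn1)C(C)(C)O` gives 66.2%
compound 2 `C[C@@H](NC(=O)c1ccc(C#CC2CC2)cn1)C(C)(C)O` gives 63.4%
compound 3 `C[C@@H](NC(=O)c1ccc(C#Cc2ccc(F)cn2)cn1)C(C)(C)O` gives 64.6%

Compound 1 has the highest of the three numbers, but the gaps are small: its nearest neighbour is compound 3, with a number 1.6 percentage points lower from compound 1 to compound 3 (within the scatter), and its furthest is compound 2, with a number 2.8 percentage points lower from compound 1 to compound 2 (within the scatter). Both steps lie within the scatter, so the three compounds cannot be placed in any order on this read-out.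

Compound 4 `C[C@@H](NC(=O)c1ccc(C#Cc2cc(F)ccn2)cn1)C(C)(C)O` is not yet measured. It differs from compound 1 in one place: 4-fluoropyridin-2-yl in place of 4-fluorophenyl on a triple-bonded carbon.

Within the data shown here, the step that bears most directly on this change is the one from compound 1 to compound 3, where a six-membered aromatic ring with one hetero atom likewise replaced the 4-fluorophenyl ring, with a number 1.6 percentage points lower from compound 1 to compound 3 (within the scatter). The step from compound 2 to compound 3, a number 1.2 percentage points higher from compound 2 to compound 3 (within the scatter), also stayed within the scatter. Nothing measured here suggests that moving to a 4-fluoropyridin-2-yl ring should change the maximal response beyond the scatter.

Compound 4 is therefore expected to give about 64.5%, in the range 56% to 73%, an estimated step of a number 1.7 percentage points lower from compound 1 to compound 4 (within the scatter).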

Compound 4, largest response reached (reported as efficacy), in percent of the reference or control that the assay uses: 66.2%
The estimate for compound 4 lay 1.7 percentage points below the measured number; measured number inside the range.
By their numbers in this assay, from the lowest: compounds 2, 3, 1 and 4 (each within the scatter of the next).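

In this assay, the 4-fluoropyridin-2-yl ring counts one hydrogen-bond acceptor where 4-fluorophenyl counts none, yet this swap on the triple-bonded carbon leaves the maximal response where it was (no change at the digits printed from compound 1 to compound 4 (within the scatter)). The two fluoropyridine groups, which hold the same atoms arranged differently, also cannot be told apart (a number 1.6 percentage points higher from compound 3 to compound 4 (within the scatter)), and neither can the 4-fluoropyridin-2-yl ring and the much smaller cyclopropyl (a number 2.8 percentage points higher from compound 2 to compound 4 (within the scatter)), so all four compounds sit within the scatter of one another and this position shows no measurable preference among these groups on this read-out. No measurement is available to explain why the response stays so flat across these groups.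

All four groups at this position are rings, which leaves open whether a different kind of group on the triple-bonded carbon, such as an amine, a carboxylic acid or a longer carbon chain, would keep the maximal response in the same band. This read-out also records only the largest response reached, so the concentration each compound needs to reach that response remains an open question.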